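The compounds below may be only part of what the source reports. "The series", "measured", "known", "first", "only" and "open" are said of these compounds alone.

Measured compounds:
- compound 1, `CC1CCCCN1C(=S)SCc1ccc(C(=O)Nc2ccccc2N)cc1`, gives 85.2%
- compound 2, `Nc1ccccc1NC(=O)c1ccc(CSC(=S)N2CCN(Cc3ccncc3)CC2)cc1`, gives 89.5%

Both compounds were tested in a functional assay on A-375 cells (Homo sapiens) for antiproliferative activity, read by CCK-8 assay, with a stated time of 72 h, tested at 8 uM; a higher number here means a stronger effect of the compound at the concentration tested, a lower number a weaker effect. Compound 1 carries the smaller of the two numbers, yet its gap to compound 2 lies within the usual scatter of repeated measurements, so the two cannot be told apart on this evidence. Among the compounds with values here, compound 1 and compound 2 differ from each other in more than one place, so no measured step for a single structural change is available here.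

Compound 3, `CN(Cc1ccncc1)C(=S)SCc1ccc(C(=O)Nc2ccccc2N)cc1`, has not yet been measured. It differs from compound 1 in one place: methyl((pyridin-4-yl)methyl)amino in place of 2-methylpiperidin-1-yl on a thiocarbonyl carbon. Compound 1 and compound 2 carry different nitrogen-containing groups on that thiocarbonyl carbon and still score much alike in this assay, which suggests the swap here will not move the number far. The step from compound 1 to compound 3 is expected to be a number 1.2 percentage points lower from compound 1 to compound 3 (within the scatter), a change that is expected to stay within the scatter, leaning slightly downward if anywhere. Compound 3 is therefore estimated to give 84% in this assay, with an expected range from 70% to 94%.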

Compound 3, a percentage reported as inhibition, at one concentration (the size of the read-out at that concentration, not a potency): 86.1%
The estimate for compound 3 lay 2.1 percentage points below the measured number; low and high end bracket the measured number.
By their numbers in this assay, from the lowest: compounds 1, 3 and 2 (each within the scatter of the next).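

In this assay, within the data shown here, this is the first comparison in which only the group on the thiocarbonyl carbon changes, and the step is a number 0.9 percentage points higher from compound 1 to compound 3 (within the scatter) within a shared core. The swap replaces a six-membered non-aromatic ring, 2-methylpiperidin-1-yl, with methyl((pyridin-4-yl)methyl)amino, which brings in a six-membered aromatic ring and a hydrogen-bond acceptor, yet the two compounds cannot be told apart at the concentration tested. This position therefore tolerates this particular exchange of amine groups, at least by this single read-out, although one pair cannot show how far that tolerance extends.

As far as these compounds go, since the read-out comes from one concentration, it remains open whether these two groups would separate at lower concentrations, where a stronger or weaker effect might show. From the compounds shown here alone, it also remains open whether a much smaller group such as dimethylamino, or a group carrying a carboxylic acid, would keep the read-out in the same range on this thiocarbonyl carbon. No measurement shown here speaks to the reason behind this result.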